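Notes on the triazole-substituent change from compound 3 to compound 4

The compounds below may be only part of what the source reports. "The series", "measured", "known", "first", "only" and "open" are said of these compounds alone.

Compound 1 `CCOC(=O)C1=Cc2ccccc2OC1(OCc1cn(CC(=O)Nc2cccc(Cl)c2)nn1)C(F)(F)F` gives 11600 nM in a functional assay on MCF7 cells (Homo sapiens) for inhibition, read by MTT assay, with a stated time of 24 h; a lower number here means a stronger inhibitor, a higher number a weaker inhibitor. Compound 3 `CCOC(=O)C1=Cc2ccccc2OC1(OCc1cn(CC(=O)Nc2ccccc2F)nn1)C(F)(F)F` gives 42100 nM in this assay. Compound 2 `CCCCCCCCn1cc(COC2(C(F)(F)F)Oc3ccccc3C=C2C(=O)OCC)nn1` reaches only a limit of this assay, > 150000 nM. Compound 3 therefore holds the higher of the two numbers shown. The nearest step is a 3.6-fold higher number from compound 1 to compound 3 (0.56 log units; beyond the scatter). Compound 4 `CCOC(=O)C1=Cc2ccccc2OC1(OCc1cn(-c2ccc([N+](=O)[O-])cc2)nn1)C(F)(F)F` is unmeasured; it differs from compound 3 by 4-nitrophenyl in place of ((2-fluorophenyl)carbamoyl)methyl on an aromatic nitrogen. Two measured steps at the same aromatic nitrogen bear on this: an at least 12-fold higher number from compound 1 to compound 2 (1.11 log units; beyond the scatter) and an at least 3.5-fold lower number from compound 2 to compound 3 (0.55 log units; beyond the scatter). In both, losing the carbamoylmethyl group raised the number, once up to the limit noted as the limit of > 150000 nM in this assay, at which 1 of the 3 values shown sits. A rise beyond the scatter is therefore expected. Compound 4 is estimated at 100000 nM, range 30000 nM to 300000 nM, the expected step being a 2.4-fold higher number from compound 3 to compound 4 (0.38 log units; beyond the scatter).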

Compound 4, half-maximal inhibitory concentration: > 150000 nM
Compound 4: a limit, no number; the forecaster's own chance of this, stated with the estimate: 40%; middle value at least 1.5-fold (0.17 log units) away from the limit.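

In this assay, 4-nitrophenyl on the aromatic nitrogen gives an at least 3.5-fold higher number from compound 3 to compound 4 (0.55 log units; beyond the scatter) and an at least 12-fold higher number from compound 1 to compound 4 (1.11 log units; beyond the scatter). Compound 4 keeps a six-membered aromatic ring, as compound 1 and compound 3 do, so that ring alone, without the carbamoylmethyl link, does not hold the number in this series. Compound 2 and compound 4 both stand at a limit, so the step between them cannot be read: the limit of > 150000 nM in this assay, at which 2 of the 4 values shown sit.

Open, as far as these compounds go, is whether a benzyl group on this nitrogen would bring the number back toward compound 1 and compound 3. An amine in place of the nitro group of the 4-nitrophenyl is equally untested by the compounds shown.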